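A few compounds are considered here, and "the series" means these few. Any claim that something is new, unique, unknown or untested is made for them only; others in the source may bear on it.

Measured so far:
Compound 1, `CCN(c1ccc(C#N)c(Cl)c1)c1cc(-c2cncnc2)ccc1C`: 3920 nM in a functional assay on VCaP cells (Homo sapiens) for antiproliferative activity, read by CCK-8 assay, with a stated time of 6 days; on this read-out lower numbers stand for stronger inhibition and higher numbers for weaker inhibition.
Compound 2, `Cc1noc(C)c1-c1cccc2c1CCCN2c1ccc(C#N)c(C(F)(F)F)c1`: > 30000 nM in this assay; this is a limit of the assay, not a number.

Compound 1 therefore holds the only actual number shown in this assay; the remaining value is a limit, as given by the limit of > 30000 nM in this assay, at which 1 of the 2 values shown sits. For the measured compounds named here, no two measured compounds differ in a single place, so no measured step is available for calibration.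

Compound 3, `CCN(c1ccc(C#N)c(Cl)c1)c1cc(-n2cccn2)ccc1C`, has not yet been measured in this assay. Relative to compound 1 it carries 1H-pyrazol-1-yl in place of pyrimidin-5-yl on an aromatic carbon. Both the group that leaves and the group that enters are small aromatic rings with two hetero atoms and no donors, so the exchange is a like-for-like swap of a heteroaromatic substituent on the same aromatic carbon of the shared core.

Given no measured step to lean on, the expectation in this assay is for no change beyond the usual scatter in either direction. The estimated step from compound 1 is expected to be a 1.1-fold higher number from compound 1 to compound 3 (0.06 log units; within the scatter). For compound 3 the expected value is 4500 nM, with a range from 1500 nM to 14000 nM.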

Compound 3, half-maximal inhibitory concentration: 2340 nM
Compound 3: middle estimate off by 1.9-fold (0.28 log units), on the high side, within the range that was stated.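

In this assay, for the compounds shown here, the exchange of pyrimidin-5-yl for 1H-pyrazol-1-yl, on the aromatic carbon para to a methyl group, gives a 1.7-fold lower number from compound 1 to compound 3 (0.22 log units; within the scatter) and is the first measured step. At this position, a six-membered and a five-membered aromatic ring, each with 2 hetero atoms and neither with a hydrogen-bond donor, therefore cannot be told apart on this read-out, so the change in ring size alone has no measurable effect in this one pair. This single step says nothing about why the two rings read alike, and no measurement shown bears on a cause for it.

On these data alone, whether a group of another kind on the same carbon, such as a morpholine, a primary amine or a carboxylic acid, would stay within the scatter of compound 1 remains open. Also open, as far as these compounds go, is whether the same exchange of rings would read alike on a core other than that of compound 1.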